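Xanthate-to-Dithiocarbamate Series: Aromatic Substituent Change

The source may hold more compounds than are shown below. What is called first, only, known or untested is meant among the compounds shown, and "the series" means these compounds.

Measured compounds:
Compound 1, `CCOC(=S)SCC(=O)c1ccc(OC)cc1`: 448 nM
Compound 2, `CCNC(=S)SCC(=O)c1ccc(OC)cc1`: 94 nM

Compound 1 gives the highest number of the two in an assay on HEK293 cells for inhibition of protein deacetylase HDAC6 (Homo sapiens); on this read-out higher numbers stand for weaker inhibition and lower numbers for stronger inhibition; its nearest neighbour is compound 2, reached by a 4.8-fold lower number from compound 1 to compound 2 (0.68 log units; beyond the scatter), an ethylamino in place of ethoxy on a thiocarbonyl carbon.

The unmeasured compound 3, `CCOC(=S)SCC(=O)c1ccc(NC(C)=O)cc1`, differs from compound 1 at a different site: acetamido in place of methoxy on an aromatic carbon. Going by the values given here, the single measured step concerns the thiocarbonyl side and not the aromatic ring, so no measured comparison bears on this change. With nothing in the series to anchor the direction, the expectation is an uncertain, at most modest step, and the estimate for compound 3 is set slightly above compound 1 with a wide range: a 1.3-fold higher number from compound 1 to compound 3 (0.13 log units; within the scatter) is expected. The expected value for compound 3 is 600 nM, with a range from 200 nM to 2000 nM.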

Compound 3, half-maximal inhibitory concentration: 90 nM
Beside the measured number, compound 3's estimate is 6.7-fold (0.82 log units) above it; the whole stated range lies above it.
By their numbers in this assay, from the lowest: compounds 3 and 2 (each within the scatter of the next); then compound 1.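

In this assay, acetamido in place of methoxy on an aromatic carbon gives a 5.0-fold lower number from compound 1 to compound 3 (0.70 log units; beyond the scatter), so the aromatic ring is a second site in this series that responds to substitution, whereas the earlier pair spoke only to the thiocarbonyl side. The entering group differs from methoxy in size and in carrying 1 hydrogen-bond donor, but a single step cannot separate these differences. No measurement available here accounts for the step.

Open, from the compounds shown here alone, is whether the amide hydrogen matters, which an N-methylacetamido group or a free amine at the same place could test. Also open, going by these compounds, is whether the two changes add up in a compound carrying ethylamino on the thiocarbonyl carbon together with acetamido on the ring.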